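A few compounds are considered here, and "the series" means these few. Any claim that something is new, unique, unknown or untested is made for them only; others in the source may bear on it.

Compound 1 `O=C(O)COc1ccc(NCc2cccc(Oc3ccccc3)c2)cc1` is one of two measured agonists in a functional assay on CHO cells for agonist activity at Free fatty acid receptor 1 (Homo sapiens), read by a luciferase reporter; a higher number here means a larger maximal response, a lower number a smaller maximal response; there compound 1 gives 84%, the lower of the two figures, while compound 2 `Cc1nc(-c2ccc(C(F)(F)F)cc2)sc1CNc1ccc(C(C)CC(=O)O)cc1` reaches 109%, a gap that lies beyond the scatter. Compound 3 `CNC(=O)CCc1ccc(NCc2cccc(Oc3ccccc3)c2)cc1` differs from compound 1 in one place: 2-(methylcarbamoyl)ethyl in place of carboxymethoxy on an aromatic carbon. Among the measured compounds shown here, because the maximal response of compound 1 is only 84% and the acid it carries is the one feature shared with compound 2, a sizeable downward step is expected, a number 44 percentage points lower from compound 1 to compound 3 (beyond the scatter). Compound 3 is therefore estimated to reach 40%, between 10% and 75%.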

Compound 3, largest response reached (reported as percent of maximum), in percent of the reference or control that the assay uses: 67%
For compound 3 the middle estimate is 27 percentage points below the measured one, and the stated range covers the measured number.
By their numbers in this assay, from the lowest: compound 3; then compound 1; then compound 2.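

In this assay, putting 2-(methylcarbamoyl)ethyl in place of carboxymethoxy on an aromatic carbon para to a large group gives a number 17 percentage points lower from compound 1 to compound 3 (beyond the scatter), a modest loss. Compound 3 carries an amide and no carboxylic acid, yet still gives 67%, so in this pair a carboxylic acid at this place is not needed for a clear maximal response. Nothing measured here explains the lower response. Still open, as far as these compounds go, is how a carboxylic acid on the same ethyl chain would compare with the amide. An amine or a tetrazole at this place also remains untested in the compounds shown.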